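A few compounds are considered here, and "the series" means these few. Any claim that something is new, unique, unknown or untested is made for them only; others in the source may bear on it.

Compound 3 `Nc1c(C(=O)c2ccc(F)cc2F)sc2nc(-c3cccs3)ccc12` gives 2.3 ug/mL in a functional assay on WI-38 VA13 cells (Homo sapiens) for cytotoxicity (on this read-out lower numbers stand for an effect already at smaller amounts and higher numbers for an effect only at larger amounts of compound), the highest of the three numbers at hand. Compound 2 `Nc1c(C(=O)c2ccc(F)cc2)sc2nc(-c3cccs3)ccc12` gives 1.8 ug/mL, and the step of a 1.3-fold higher number from compound 2 to compound 3 (0.11 log units; within the scatter) lies within the scatter. Compound 1 `COc1ccccc1C(=O)c1sc2nc(-c3cccs3)ccc2c1N` gives 0.059 ug/mL, far apart from both: a 31-fold higher number from compound 1 to compound 2 (1.48 log units; beyond the scatter) and a 39-fold higher number from compound 1 to compound 3 (1.59 log units; beyond the scatter). Compound 4 `Nc1c(C(=O)c2ccc(Br)cc2)sc2nc(-c3cccs3)ccc12` differs from compound 3 by 4-bromophenyl in place of 2,4-difluorophenyl on a carbonyl carbon. The two large steps show that exchanging the whole aryl group on the carbonyl carbon can move this assay a long way, while the small step from compound 2 to compound 3 shows that a halogen change on that ring need not. Because both compound 2 1.8 ug/mL and compound 3 2.3 ug/mL carry halogenated phenyl groups, compound 4 is expected to stay near them, a step of a 1.4-fold lower number from compound 3 to compound 4 (0.16 log units; within the scatter) of no more than the scatter, estimated at 1.6 ug/mL within 0.4 ug/mL to 6 ug/mL.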

Compound 4, half-maximal effective concentration: 2.8 ug/mL
Compound 4: the middle estimate sits 1.8-fold (0.24 log units) below what was measured; measured number inside the range.
By their numbers in this assay, from the lowest: compound 1; then compounds 2, 3 and 4 (each within the scatter of the next).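

In this assay the exchange for 4-bromophenyl on the carbonyl carbon gives a 1.2-fold higher number from compound 3 to compound 4 (0.09 log units; within the scatter) and bromo in place of fluoro on an aromatic carbon gives a 1.6-fold higher number from compound 2 to compound 4 (0.19 log units; within the scatter) so a heavier halogen at this position leaves the number within the scatter, as the added fluoro did. The step of a 47-fold higher number from compound 1 to compound 4 (1.68 log units; beyond the scatter) is a large one. Among these compounds, compound 4 thus stands with compounds 2 and 3, apart from compound 1, and no halogenated compound here goes against that. Nothing given here explains this separation. On these data alone, whether a 4-methoxyphenyl or a plain phenyl group on the carbonyl carbon would stand with compound 1 or with the halogenated compounds remains open.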